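Working notes: from compound 2 to compound 3

The compounds below may be only part of what the source reports. "The series", "measured", "known", "first", "only" and "open" are said of these compounds alone.

Measured in a physicochemical assay for solubility, read by chemiluminescence, measured as kinetic solubility; on this read-out higher numbers stand for higher solubility and lower numbers for lower solubility:
- compound 1 `O=C([C@H]1CCCCN1)N1CCC2(CCN(c3nccc(NCc4ccc(Cl)cc4Cl)n3)CC2)C1`: 172 ug/mL
- compound 2 `O=C(C1COCCN1)N1CCC2(CCN(c3nccc(NCc4ccc(Cl)cc4Cl)n3)CC2)C1`: 233 ug/mL

Not yet measured: compound 3 `Clc1ccc(CNc2ccnc(N3CCC4(CCN(C[C@@H]5CCCN5)C4)CC3)n2)c(Cl)c1`

Within the data shown here, compound 2 stands within the scatter of compound 1, the only other number so far. Compound 3 carries this change: (pyrrolidin-2-yl)methyl in place of (morpholin-3-yl)carbonyl on an amine nitrogen in a ring. Among the measured compounds shown here, the one measured step, a 1.4-fold higher number from compound 1 to compound 2 (0.13 log units; within the scatter), swaps morpholin-3-yl for piperidin-2-yl on a carbonyl carbon and leaves the carbonyl in place. For the measured compounds named here, it is a different change, so it gives only weak guidance, and no measured step covers the loss of the carbonyl. In this assay, no step beyond the scatter is expected, with wide uncertainty. The expected step is a 1.0-fold lower number from compound 2 to compound 3 (0.01 log units; within the scatter). For compound 3 the estimated value is 230 ug/mL, with an expected range of 100 ug/mL to 500 ug/mL.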

Compound 3, solubility: 56 ug/mL
For compound 3 the middle estimate is 4.1-fold (0.61 log units) above the measured one; measured number below the stated range.
By their numbers in this assay, from the lowest: compound 3; then compounds 1 and 2 (each within the scatter of the next).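

In this assay the amine nitrogen in a ring proves sensitive to its substituent: (pyrrolidin-2-yl)methyl gives a 4.2-fold lower number from compound 2 to compound 3 (0.62 log units; beyond the scatter) and a 3.1-fold lower number from compound 1 to compound 3 (0.49 log units; beyond the scatter) while the ring swap on the carbonyl carbon stayed within the scatter. Both steps beyond the scatter come with loss of the carbonyl. No supporting data bear on the origin of this drop.

Each step changes the ring and removes the carbonyl at once, leaving their shares unresolved. (Pyrrolidin-2-yl)carbonyl or (morpholin-3-yl)methyl on the same nitrogen would separate the two.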